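The source may hold more compounds than are shown below. What is called first, only, known or untested is meant among the compounds shown, and "the series" means these compounds.

Among the compounds with values here, in a functional assay on MKN-45 cells (Homo sapiens) for cytotoxicity (a higher number here means a weaker inhibitor, a lower number a stronger inhibitor), compound 2 (`COc1ccc(S(=O)(=O)N2CCc3cccc(N)c32)cc1`) gives 1200 nM, the higher of the two numbers so far and clearly beyond the scatter from compound 1 (`COc1ccc(S(=O)(=O)N2CCc3cccc(NC(=O)c4ccc([N+](=O)[O-])cc4)c32)cc1`), which gives 95 nM. Compound 3 (`COc1ccc(C(=O)Nc2cccc3c2N(S(=O)(=O)c2ccc(OC)cc2)CC3)cc1`) has not yet been measured. It carries (4-methoxyphenyl)carbonyl in place of hydrogen on a nitrogen on an aromatic ring of compound 2 ((4-methoxyphenyl)carbonyl in place of hydrogen on a nitrogen on an aromatic ring). Compound 1, also acylated on that nitrogen, stands at 95 nM, so a lower number is expected here. The expected step is a 10-fold lower number from compound 2 to compound 3 (1.00 log units; beyond the scatter), beyond the scatter and towards stronger inhibition. Compound 3 is estimated at 120 nM, with an expected range of 30 nM to 500 nM.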

Compound 3, half-maximal inhibitory concentration: 1600 nM
Estimate against measurement, compound 3: 13-fold (1.12 log units) below; measured number outside the range, above it.
By their numbers in this assay, from the lowest: compound 1; then compounds 2 and 3 (each within the scatter of the next).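

In this assay, putting (4-methoxyphenyl)carbonyl in place of hydrogen on the nitrogen gives a 1.3-fold higher number from compound 2 to compound 3 (0.12 log units; within the scatter), so acylation at this position does not by itself go with a lower number. Methoxy in place of nitro on an aromatic carbon gives a 17-fold higher number from compound 1 to compound 3 (1.23 log units; beyond the scatter), which ties the low number of compound 1 to the nitro group within this pair of amides. No measurement shown here explains this difference.

The compounds shown leave open whether a nitrile, a chlorine or a carboxylic acid on that aromatic carbon would stand with compound 1 or with compound 3. They also leave open how an acetyl group on the nitrogen would compare.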